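A few compounds are considered here, and "the series" means these few. Any claim that something is new, unique, unknown or untested is made for them only; others in the source may bear on it.

Working notes on the series. In a physicochemical assay for lipophilicity, read by HPLC, measured as chromatographic lipophilicity, at pH 7.4 (on this read-out higher numbers stand for higher lipophilicity and lower numbers for lower lipophilicity), compound 1 `O=C(C1CCN(c2ncccn2)CC1)N1N=CC[C@H]1c1ccccc1` reads 4.7 and compound 2 `CC(C)(C)C(=O)N1CCSC1c1ccccc1` reads 5.6 which leaves compound 1 with the lower of the two numbers, by a gap beyond the usual scatter. Compound 3 `O=C(C1CCN(c2ccncn2)CC1)N1N=CC[C@H]1c1ccccc1` is still unmeasured and keeps the core of compound 1 apart from one place. The change pyrimidin-4-yl in place of pyrimidin-2-yl on an amine nitrogen in a ring puts pyrimidin-4-yl in place of pyrimidin-2-yl on an amine nitrogen in a ring. The two groups have the same atoms, joined differently, so the counts alone give no direction. Within the data shown here, no measured pair shows this change, and the expectation rests on the structural change alone. The expected step of a number 0.80 log units lower from compound 1 to compound 3 (beyond the scatter) in this assay points downward, moderately beyond the scatter. The estimate for compound 3 is 3.9 with an expected range from 3.4 to 4.4 until a measurement exists.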

Compound 3, distribution coefficient: 3.2
Beside the measured number, compound 3's estimate is 0.70 log units above it, outside the stated range (below it).
By their numbers in this assay, from the lowest: compound 3; then compound 1; then compound 2.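

Among these compounds, putting pyrimidin-4-yl in place of pyrimidin-2-yl on an amine nitrogen in a ring gives the first one-place step, a number 1.50 log units lower from compound 1 to compound 3 (beyond the scatter), in this assay. This place on the core of compound 1 is therefore sensitive to how the group is joined, not only to what it contains, since the two groups have the same atoms and the same counts of donors and acceptors. Nothing in hand accounts for the size of this step.

On these data alone, whether a pyridin-2-yl, pyridin-4-yl or plain phenyl group at this place would read closer to compound 1 or to compound 3 remains open. Also open, as far as these compounds go, is whether an amine or a methoxy group on the pyrimidin-4-yl ring would shift the number away from that of compound 3, 3.2 in this assay.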